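Thiosemicarbazide-linked pyridyl amidrazones: growth inhibition on A-431 cells

The source may report more compounds than this note shows. Statements on the series, on what has been measured and on what is new or still open speak of the compounds shown alone.

Measured so far:
- compound 1, `Cc1ccnc(/C(N)=N/NC(=S)N2CCCC2)c1`: 58.5%
- compound 2, `N/C(=N\NC(=S)N1CCSCC1)c1ccccn1`: 31.7%
- compound 3, `N/C(=N\NC(=S)N1CCN(c2ccccn2)CC1)c1ccc(F)cn1`: 31.1%

All three were run in a functional assay on A-431 cells (Homo sapiens) for cytotoxicity, read by MTT assay, with a stated time of 72 h, tested at 1 uM; on this read-out higher numbers stand for more inhibition of growth at the one concentration tested and lower numbers for less inhibition of growth. Compound 3 gives the lowest of the three numbers, yet compound 2 sits within the usual scatter of it, so no order between these two can be read. Only compound 1 stands apart, its number lying beyond the scatter above that of compound 3.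

The next compound, compound 4, `Cc1ccnc(/C(N)=N/NC(=S)N2CCN(c3ccccn3)CC2)c1`, is derived from compound 3 by a single change: 4-methylpyridin-2-yl in place of 5-fluoropyridin-2-yl on a carbon with a double bond to nitrogen. The rest of the molecule is kept. Within the data shown here, no pair of measured compounds differs only at this place, so the size of this step is not known from the data. Among the measured compounds shown here, what the numbers do show is that compound 1, the one measured compound carrying the 4-methylpyridin-2-yl group, gives 58.5%, while both compounds without it lie lower. On that basis the step in this assay is expected to be modest and upward, a number 13.9 percentage points higher from compound 3 to compound 4 (beyond the scatter), though a step within the scatter cannot be ruled out. Compound 4 is therefore estimated at 45%, with a range of 25% to 65%.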

Compound 4, percent growth inhibition at one concentration: 28.9%
The estimate for compound 4 lay 16.1 percentage points above the measured number; low and high end bracket the measured number.
By their numbers in this assay, from the lowest: compounds 4, 3 and 2 (each within the scatter of the next); then compound 1.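

In this assay, 4-methylpyridin-2-yl in place of 5-fluoropyridin-2-yl on the carbon with a double bond to nitrogen gives a number 2.2 percentage points lower from compound 3 to compound 4 (within the scatter) and so no readable change at this position, with the rest of the molecule held constant. The 4-methylpyridin-2-yl group alone therefore does not go with a high number: compound 4 gives 28.9% for the same assay, while compound 1, which carries that group with a different group at the other end of the molecule, gives 58.5% there. Nothing at hand explains the absence of a readable step. Still open, from the compounds shown here alone, is whether this exchange would also leave the number unchanged with the rest of compound 1 in place. Also open, going by these compounds, is whether an amine or a carboxylic acid on the pyridine ring would move the number at this position.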